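Bromo-to-ethoxy step on the anilide of compound 3

The compounds below may be only part of what the source reports. "The series", "measured", "known", "first", "only" and "open" are said of these compounds alone.

Measured so far in a functional assay on MCF7 cells (Homo sapiens) for cytotoxicity, read by MTT assay, with a stated time of 48 h; a lower number here means a stronger inhibitor, a higher number a weaker inhibitor:
compound 1 `O=C(Nc1ccc(Br)cc1)c1cn(-c2ccccc2)nc1-c1ccccc1` gives 5750 nM
compound 2 `CCOc1ccc(NC(=O)c2cn(-c3ccccc3)nc2-c2ccccc2)cc1` gives 880 nM
compound 3 `COc1ccc(-c2nn(-c3ccccc3)cc2C(=O)Nc2ccc(Br)cc2)cc1` gives 8210 nM

Compound 3 holds the highest of the three numbers in this assay. The step of a 1.4-fold higher number from compound 1 to compound 3 (0.15 log units; within the scatter) shows that the methoxy on the pendant ring leaves the read-out where it was, and those two compounds sit together. Its gap to compound 2 is wider: compound 2 gives 880 nM against the value of compound 3 above, and that gap is beyond the scatter.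

Compound 4 `CCOc1ccc(NC(=O)c2cn(-c3ccccc3)nc2-c2ccc(OC)cc2)cc1` is the next point. It differs from compound 3 by ethoxy in place of bromo on an aromatic carbon. Among the compounds with values here, one measured step bears on this directly: the same swap on the compound without the methoxy, a 6.5-fold lower number from compound 1 to compound 2 (0.82 log units; beyond the scatter), which was a modest drop beyond the scatter. The other step, a 1.4-fold higher number from compound 1 to compound 3 (0.15 log units; within the scatter), shows that adding the methoxy did not move the number; nothing measured says it would alter the response to the ethoxy swap. The expectation is therefore a drop of about the size seen before, a 6.6-fold lower number from compound 3 to compound 4 (0.82 log units; beyond the scatter), bringing compound 4 into the neighbourhood of compound 2. Compound 4 is estimated at 1250 nM in this assay, with a range from 400 nM to 4000 nM.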

Compound 4, half-maximal inhibitory concentration: 1100 nM
Compound 4: the middle estimate sits 1.1-fold (0.06 log units) above what was measured; the measured number falls inside the stated range.
By their numbers in this assay, from the lowest: compounds 2 and 4 (each within the scatter of the next); then compounds 1 and 3 (each within the scatter of the next).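

In this assay the change from 4-bromophenyl to 4-ethoxyphenyl now reads on a second core (a 7.5-fold lower number from compound 3 to compound 4 (0.87 log units; beyond the scatter)), with the methoxy present, and the drop is of matching size on both, so it is not tied to the compound on which it was first seen: the same change on two cores in this assay, a 6.5-fold lower number (0.82 log units; beyond the scatter) from compound 1 to compound 2 and a 7.5-fold lower number (0.87 log units; beyond the scatter) from compound 3 to compound 4, 1.1-fold (0.06 log units) apart, within the scatter of two such steps

The methoxy in place of hydrogen, until now read only with bromo on the other ring, also stays within the scatter with ethoxy there (a 1.3-fold higher number from compound 2 to compound 4 (0.10 log units; within the scatter)), and the two changes read as independent of one another across these four compounds: the same change on two cores in this assay, a 1.4-fold higher number (0.15 log units; within the scatter) from compound 1 to compound 3 and a 1.3-fold higher number (0.10 log units; within the scatter) from compound 2 to compound 4, 1.1-fold (0.06 log units) apart, within the scatter of two such steps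

Within the data shown here, the number therefore follows the group at the position para to a large group and not the methoxy, with compound 2 and compound 4 together in the lower pair, compound 1 and compound 3 together in the upper pair, and no compound of the four going against that split.

As far as these compounds go, the series spans just bromo and ethoxy at this position, so it remains open whether the drop belongs to an oxygen-linked chain as such, and how a hydroxyl, an amine or a longer chain such as butoxy would read there. From the compounds shown here alone, it is equally open whether the methoxy stays silent when moved elsewhere on its ring, or whether a carboxylic acid in its place would still leave the number unmoved.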